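Replacing 3-(methoxycarbonyl)phenyl with pyridin-2-yl

A few compounds are considered here, and "the series" means these few. Any claim that something is new, unique, unknown or untested is made for them only; others in the source may bear on it.

Measured in an ADME assay on S9 fraction from liver (Rattus norvegicus) for metabolic stability, read by LC-MS, using NADPH, with a stated time of 30 min; on this read-out lower numbers stand for a less stable compound and higher numbers for a more stable compound:
- Compound 1 `CCCCCCCCc1ccc(OCC(=O)Cn2nnc(SC)n2)cc1`: < 5% (a limit of the assay, not a number)
- Compound 2 `CCCCCCCCc1ccc(OCC(=O)Cn2nnc(-c3ccccc3)n2)cc1`: 33%
- Compound 3 `CCCCCCCCc1ccc(OCC(=O)Cn2nnc(-c3cccc(C(=O)OC)c3)n2)cc1`: 19%

Compound 3 has the lower of the two true numbers, and the closest comparison is a number 14 percentage points lower from compound 2 to compound 3 (beyond the scatter). That step adds methoxycarbonyl in place of hydrogen on an aromatic carbon. Compound 4 `CCCCCCCCc1ccc(OCC(=O)Cn2nnc(-c3ccccn3)n2)cc1` carries pyridin-2-yl in place of 3-(methoxycarbonyl)phenyl on an aromatic carbon.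

Two further steps, a number at least 28 percentage points higher from compound 1 to compound 2 (beyond the scatter) and a number at least 14 percentage points higher from compound 1 to compound 3 (beyond the scatter), start from a limit and so give only a rough size. Pyridin-2-yl has no methoxycarbonyl, like the phenyl of compound 2 at 33%, so a small rise, not beyond the scatter, is expected. The estimated step is a number 6 percentage points higher from compound 3 to compound 4 (within the scatter). For compound 4 the expected value is 25%, with an estimated range of 9% to 45%.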

Compound 4, percent of the compound remaining: 30%
Compound 4: the middle estimate sits 5 percentage points below what was measured, within the range that was stated.
By their numbers in this assay, from the lowest: compound 3; then compounds 4 and 2 (each within the scatter of the next). At a limit, below all of these: compound 1.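

In this assay, pyridin-2-yl gives a number 11 percentage points higher from compound 3 to compound 4 (beyond the scatter), and also a number 3 percentage points lower from compound 2 to compound 4 (within the scatter). A ring nitrogen can therefore enter this position with no change beyond the scatter from the plain phenyl. A third step, a number at least 25 percentage points higher from compound 1 to compound 4 (beyond the scatter), starts from a limit of the assay and gives only a rough size: the limit of < 5% in this assay, at which 1 of the 4 values shown sits.

On these data alone, it remains open how a carboxylic acid in place of the methoxycarbonyl of compound 3 would read in this assay. An amine on the pyridin-2-yl ring of compound 4 is equally untested by these values.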